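The compounds below may be only part of what the source reports. "The series", "measured", "known", "first", "only" and "open" are said of these compounds alone.

Compound 1 `Nc1nc(Cl)c(-c2nc3ccccc3s2)c(N[C@@H]2C[C@H](CO)[C@@H](O)[C@H]2O)n1`: in an ADME assay on cells (Homo sapiens) for cytotoxicity, read by polymerase chain reaction, with a stated time of 3 days (on this read-out lower numbers stand for higher toxicity in this test and higher numbers for lower toxicity in this test), compound 1 gives 14000 nM.
Compound 2 `CNc1ccc2sc(-c3c(Cl)nc(N)nc3N[C@@H]3C[C@H](CO)[C@@H](O)[C@H]3O)nc2c1`: in this assay compound 2 gives 20000 nM.
Compound 3 `Nc1ncc(-c2nc3ccccc3s2)c(N[C@@H]2C[C@H](CO)[C@@H](O)[C@H]2O)n1`: in this assay compound 3 reaches only > 25000 nM, which is a limit of the test and not a number.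

All three compounds share one core and differ at a single aromatic carbon. For compound 3 only a limit is known, so its exact number is not settled, and the limit of > 25000 nM in this assay, at which 1 of the 3 values shown sits, shows how common such a limit is among the values shown. Compound 4 `Cc1nc(N)nc(N[C@@H]2C[C@H](CO)[C@@H](O)[C@H]2O)c1-c1nc2ccccc2s1` has not been measured; compared with compound 3 it carries methyl in place of hydrogen on an aromatic carbon. Within the data shown here, two measured steps bear on a change of this kind. Replacing hydrogen with methylamino gave a 1.4-fold higher number from compound 1 to compound 2 (0.15 log units; within the scatter). Replacing chloro with hydrogen gave an at least 1.7-fold higher number from compound 1 to compound 3 (0.25 log units; that floor lies within the scatter). Both steps are small, so for a methyl entering in place of hydrogen no step beyond the scatter is expected in this assay; the estimated step is a number no higher from compound 3 to compound 4 (the limit leaves the size open). Compound 4 is therefore expected to give about 25000 nM, in a range from 10000 nM to 60000 nM, with a fair chance that the test again reports only a limit.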

Compound 4, half-maximal cytotoxic concentration: 4000 nM
For compound 4 the middle estimate is 6.3-fold (0.80 log units) above the measured one, outside the stated range (below it).
By their numbers in this assay, from the lowest: compound 4; then compounds 1 and 2 (each within the scatter of the next). At a limit, above all of these: compound 3.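

In this assay, the earlier step at this aromatic carbon, chloro to hydrogen, showed nothing beyond the scatter, but methyl in place of hydrogen here gives an at least 6.2-fold lower number from compound 3 to compound 4 (0.79 log units; beyond the scatter), so this position does respond in this test. Methyl in place of chloro at the same carbon gives a 3.5-fold lower number from compound 1 to compound 4 (0.54 log units; beyond the scatter), which sets methyl apart from both hydrogen and chloro here, although it is a small group that adds only one carbon. Going by these compounds, compound 3 is known only through a limit, so the first of these steps is a floor and its full size remains unknown: the limit of > 25000 nM in this assay, at which 1 of the 4 values shown sits.

What an ethyl, a methoxy or an amine at this carbon would give stays open, so the compounds shown cannot tell whether the lower number belongs to methyl alone or to carbon groups here in general. They also give no reason for the drop, and they cannot say whether methyl at this carbon would act the same way alongside the methylamino group of compound 2.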